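The source may hold more compounds than are shown below. What is called first, only, known or untested is meant among the compounds shown, and "the series" means these compounds.

Measured compounds in the series:
- compound 1, `COc1cc(C)cc(-c2c(-c3ccnc(-c4ccc(C(C)=O)cc4)c3)cnn2CC#N)c1`: in a functional assay on NCI/ADR-RES cells (Homo sapiens) for inhibition, read by sulforhodamine B assay, with a stated time of 48 h (on this read-out lower numbers stand for stronger inhibition of growth and higher numbers for weaker inhibition of growth), compound 1 reports only a limit, > 100000 nM.
- compound 2, `Cc1cc(O)cc(-c2nn(CC#N)cc2-c2ccnc(-c3ccc(Oc4ccccc4)cc3)c2)c1`: in this assay compound 2 gives 4560 nM.
- compound 3, `Cc1cc(O)cc(-c2nn(CC#N)cc2-c2ccnc(-c3ccc(N(C)C)cc3)c2)c1`: in this assay compound 3 gives 7930 nM.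

Compound 1 thus stands outside the measured range in this assay; its value is a limit and not a number, so where it sits among the measured compounds cannot be said beyond that (the limit of > 100000 nM in this assay, at which 1 of the 3 values shown sits).

Compound 4, `COc1cc(C)cc(-c2c(-c3ccnc(-c4ccc(N(C)C)cc4)c3)cnn2CC#N)c1`, is to be measured in this assay. It differs from compound 1 by dimethylamino in place of acetyl on an aromatic carbon.

For the measured compounds named here, the only measured step that touches the entering group is a 1.7-fold higher number from compound 2 to compound 3 (0.24 log units; within the scatter), where dimethylamino replaced phenoxy on the same aromatic carbon of a core otherwise carrying a hydroxy group. Going by the values given here, that step shows dimethylamino as roughly neutral against phenoxy, but no measured step exchanges acetyl for anything, and compound 1 itself gives only a limit, so the size of the step to compound 4 in this assay is open. Compounds 2 and 3 show that the core can give measurable growth inhibition when the group at this position is phenoxy or dimethylamino, which leaves room for compound 4 to come back within range.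

Compound 4 is expected to give 50000 nM, with a range of 12000 nM to 150000 nM, meaning an estimated step of an at least 2.0-fold lower number from compound 1 to compound 4 (0.30 log units; that floor lies within the scatter).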

Compound 4, concentration for total growth inhibition: > 100000 nM
Compound 4: only a limit was reported (the forecaster's own chance of this, stated with the estimate: 45%); at least 2.0-fold (0.30 log units) between middle value and limit.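

In this assay compound 4 reports only a limit, > 100000 nM. Compound 1 also reports only a limit, so no step from compound 1 to compound 4 can be read: the limit of > 100000 nM in this assay, at which 2 of the 4 values shown sit.

The compounds shown leave open whether 4-acetylphenyl or 4-(dimethylamino)phenyl gives any measurable inhibition of growth on the core of compound 1.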